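Working notes on compounds 1 to 4 in one cell assay

The source may hold more compounds than are shown below. What is called first, only, known or untested is meant among the compounds shown, and "the series" means these compounds.

Measured so far:
Compound 1, `CNC(=O)/C=C/CN1CC(Oc2ccc(Oc3c(-c4ccc(F)cc4)sc4cc(O)ccc34)cc2)C1`. In a functional assay on MCF7 cells (Homo sapiens) for antiproliferative activity, read by CCK-8 assay, with a stated time of 48 h (on this read-out lower numbers stand for stronger inhibition and higher numbers for weaker inhibition), compound 1 gives > 25000 nM, which is a limit of the assay rather than a number.
Compound 2, `C=C(C)C(=O)NCCOc1ccc(Oc2c(-c3ccc(F)cc3)sc3cc(O)ccc23)cc1`. In this assay compound 2 gives > 25000 nM, again a limit of the assay.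
Compound 3, `C/C=C/C(=O)N1CC(Oc2ccc(Oc3c(-c4ccc(F)cc4)sc4cc(O)ccc34)cc2)C1`. In this assay compound 3 gives 28000 nM.

For the measured compounds named here, compound 3 thus stands as the only real number among the three; the other two sit at the limit of > 25000 nM in this assay, at which 2 of the 3 values shown sit. The steps a step that the two limits leave unreadable from compound 1 to compound 2, a step that the limit leaves unreadable from compound 1 to compound 3 and a step that the limit leaves unreadable from compound 2 to compound 3 are all unreadable in size, since each involves at least one limit.

Compound 4, `C=CC(=O)N1CC(Oc2ccc(Oc3c(-c4ccc(F)cc4)sc4cc(O)ccc34)cc2)C1`, differs from compound 3 by vinyl in place of prop-1-en-1-yl on a carbonyl carbon. Going by the values given here, none of the measured steps touches this position, and none has a readable size, so there is no precedent for it. A small trimming of the chain on the carbonyl carbon is expected to leave compound 3 and compound 4 within the scatter of each other, a step of a 1.1-fold lower number from compound 3 to compound 4 (0.05 log units; within the scatter). Compound 4 is therefore estimated at 25000 nM, within 10000 nM to 60000 nM, with a real chance that only a limit is reported.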

Compound 4, half-maximal inhibitory concentration: 23500 nM
For compound 4 the middle estimate is 1.1-fold (0.03 log units) above the measured one; the measured number falls inside the stated range.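

In this assay, for the compounds shown here, the carbonyl carbon now has the first step of readable size (a 1.2-fold lower number from compound 3 to compound 4 (0.08 log units; within the scatter)), and vinyl and prop-1-en-1-yl cannot be told apart there. Moving from prop-1-en-1-yl to vinyl therefore leaves the number within the scatter, so this change on its own gives no handle on the activity. The other two new steps (an at least 1.0-fold lower number from compound 2 to compound 4 (0.02 log units; that floor lies within the scatter) and an at least 1.0-fold lower number from compound 1 to compound 4 (0.02 log units; that floor lies within the scatter)) give only floors, and each starts from a limit of the assay: the limit of > 25000 nM in this assay, at which 2 of the 4 values shown sit.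

Open, from the compounds shown here alone, is whether any other group on the carbonyl carbon, such as a dimethylaminomethyl-substituted vinyl or a longer chain, would move the number beyond the scatter. Also open, going by these compounds, is how a plain amine would read in place of the 1-(vinylcarbonyl)azetidin-3-yl group.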